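A few compounds are considered here, and "the series" means these few. Any claim that something is new, unique, unknown or untested is made for them only; others in the source may bear on it.

Measured so far in a functional assay on UACC-62 cells (Homo sapiens) for inhibition, read by sulforhodamine B assay, with a stated time of 48 h; on this read-out higher numbers stand for weaker inhibition of growth and lower numbers for stronger inhibition of growth:

Compound 1, `CC1=CC[C@H](C(C)(C)NC(=S)N/N=C/c2ccccc2O)CC1` — compound 1 gives 2800 nM.
Compound 2, `CC1=CC[C@H](C(C)(C)NC(=S)N/N=C/c2ccccc2Cl)CC1` — compound 2 gives 19300 nM.

Compound 2 holds the highest of the two numbers in this assay; its nearest neighbour is compound 1, reached by the step of a 6.9-fold higher number from compound 1 to compound 2 (0.84 log units; beyond the scatter). Among the measured compounds shown here, that is the only step measured, and it swaps hydroxy for chloro on an aromatic carbon of the shared core.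

Compound 3, `CC1=CC[C@H](C(C)(C)NC(=S)N/N=C/c2ccccc2[N+](=O)[O-])CC1`, is not yet measured. It differs from compound 2 by nitro in place of chloro on an aromatic carbon; the group sits on an aromatic carbon of a six-membered aromatic ring of carbon only, ortho to a large group. For the measured compounds named here, no measured step compares nitro with chloro, so the one step available bears on it only loosely: it shows that exchanging the substituent at this carbon can move the number well beyond the scatter. Without a direct precedent, the step of a 1.3-fold lower number from compound 2 to compound 3 (0.11 log units; within the scatter) is expected to stay small, and compound 3 is estimated at 15000 nM, with a range from 5000 nM to 45000 nM.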

Compound 3, concentration for 50% growth inhibition: 10600 nM
For compound 3 the middle estimate is 1.4-fold (0.15 log units) above the measured one; measured number inside the range.
By their numbers in this assay, from the lowest: compound 1; then compounds 3 and 2 (each within the scatter of the next).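

In this assay, this aromatic carbon does not separate nitro from chloro, since the exchange gives a 1.8-fold lower number from compound 2 to compound 3 (0.26 log units; within the scatter), although the two groups differ in heavy atoms and hydrogen-bond acceptors. The new compound also shows that the gap first seen with chloro is not confined to that group: hydroxy stays apart from nitro as well, with a 3.8-fold higher number from compound 1 to compound 3 (0.58 log units; beyond the scatter), so among these three groups compound 1 alone stands out with the lowest number, and neither of the other compounds goes against this. No measurement offered here accounts for this grouping of the three compounds.

The compounds shown leave open whether an amine or a methoxy group on this aromatic carbon would fall with hydroxy or with chloro and nitro, and so what separates hydroxy from the other two groups remains unsettled. They also leave open whether the same grouping would hold if the rest of the shared core were changed, as every comparison here rests on this single carbon and on one cell line.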